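Swapping Methyl for Nitro on a Shared Core

The compounds below may be only part of what the source reports. "The series", "measured", "known", "first", "only" and "open" are said of these compounds alone.

Of the compounds shown here, three built on one shared core have been tested in an assay on isolated protein for inhibition of complement C1r subcomponent (Homo sapiens); on this read-out lower numbers stand for stronger inhibition and higher numbers for weaker inhibition. Compound 1 `O=c1oc(-c2ccccc2I)nc2cc(Cl)ccc12` carries a chloro group; in this assay compound 1 gives > 62500 nM, which is a limit of the assay rather than a number. Compound 2 `Cc1ccc2c(=O)oc(-c3ccccc3I)nc2c1` carries a methyl instead; in this assay compound 2 gives > 62500 nM, again a limit. Compound 3 `COc1cc2nc(-c3ccccc3I)oc(=O)c2cc1OC` carries two methoxy groups; in this assay compound 3 gives > 62500 nM, also a limit. Within the data shown here, because every value sits at the limit of > 62500 nM in this assay, at which 3 of the 3 values shown sit, the only step between compounds that differ in one place, a step that the two limits leave unreadable from compound 1 to compound 2, cannot be read in size or direction. Compound 2 therefore stands only at a limit, with nothing to rank it against compound 1 or compound 3.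

Compound 4 `O=c1oc(-c2ccccc2I)nc2cc([N+](=O)[O-])ccc12` differs from compound 2 by nitro in place of methyl on an aromatic carbon. Among the measured compounds shown here, no measured step bears on this change, since a step that the two limits leave unreadable from compound 1 to compound 2 is unreadable. There is thus no ground to expect a step in this assay beyond the scatter in either direction, and a further limit is the likeliest outcome. Compound 4 is expected at 100000 nM, in the range 30000 nM to 300000 nM. This estimate means a step that the limit leaves unreadable from compound 2 to compound 4, expected to be nothing beyond the scatter.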

Compound 4, half-maximal inhibitory concentration: 22000 nM
Compound 4: the middle estimate sits 4.5-fold (0.66 log units) above what was measured, and the stated range ends above it.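

Among these compounds, at this aromatic carbon, the group present can move the read-out in this assay, which the earlier compounds could not show. Nitro in place of methyl gives an at least 2.8-fold lower number from compound 2 to compound 4 (0.45 log units; beyond the scatter), and nitro in place of chloro gives an at least 2.8-fold lower number from compound 1 to compound 4 (0.45 log units; beyond the scatter). Both steps are minimum sizes, and compound 4 is the only one of the four compounds with a readable number, while the others remain at a limit: the limit of > 62500 nM in this assay, at which 3 of the 4 values shown sit.

The compounds shown leave open whether an amine, a carboxylic acid or a nitrile on this same aromatic carbon would also give a readable number, and whether any of them would give a lower number than compound 4, which gives 22000 nM. They also leave open how large the two steps really are, and whether nitro would give a readable number on a core that also carries a methoxy group, as compound 3 carries two.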